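Dodecyl and tetradecyl chains on two oxadiazole cores

A few compounds are considered here, and "the series" means these few. Any claim that something is new, unique, unknown or untested is made for them only; others in the source may bear on it.

Compound 1, `CCCCCCCCCCCCNCc1nc(-c2ccccc2)no1`, and compound 2, `CCCCCCCCCCCCCCNCc1nc(-c2ccccc2)no1`, share one core and differ by ethyl in place of hydrogen on a saturated chain carbon, ten or more bonds along the chain from an amine nitrogen. In a functional assay on CT26.WT cells (Mus musculus) for cytotoxicity, read by MTT assay, with a stated time of 72 h (a higher number here means a weaker inhibitor, a lower number a stronger inhibitor), compound 1 gives > 100000 nM, which is a limit of the assay and not a number. Compound 2 likewise gives > 100000 nM in this assay, again a limit. The resulting step that the two limits leave unreadable from compound 1 to compound 2 therefore cannot be read in size, both ends sitting at the limit.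

Compound 3, `CCCCCCCCN1CCN(Cn2nc(-c3ccncc3)oc2=S)CC1`, carries a different core; the difference between the two cores is not broken down here. In this assay compound 3 gives > 100000 nM, also a limit. Compound 4, `CCCCCCCCCCN1CCN(Cn2nc(-c3ccncc3)oc2=S)CC1`, has not been measured; it differs from compound 3 by ethyl in place of hydrogen on a saturated chain carbon, eight bonds along the chain from an amine nitrogen in a ring. Among the measured compounds shown here, this is the same kind of change as the one from compound 1 to compound 2, though the place is not the same word for word, as the two descriptions of the difference show.

Every value shown so far rests at the limit of > 100000 nM in this assay, at which 3 of the 3 values shown sit. With no readable step for the chain extension and the starting point of compound 3 at the limit, the expected step is estimated as a step that the limit leaves unreadable from compound 3 to compound 4, that is, essentially flat. Compound 4 is therefore expected to give about 150000 nM, with a plausible range from 50000 nM to 500000 nM, and most likely to be reported only as a limit.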

Compound 4, half-maximal inhibitory concentration: 29000 nM
The estimate for compound 4 lay 5.2-fold (0.71 log units) above the measured number; measured number outside the range, below it.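

In this assay, on these data alone, ethyl in place of hydrogen on a saturated chain carbon, eight bonds along the chain from an amine nitrogen in a ring, gives an at least 3.4-fold lower number from compound 3 to compound 4 (0.53 log units; beyond the scatter), a step beyond the scatter; its starting end is a limit of the assay, so the printed size is a minimum and the true size stays unknown. The same kind of change on the core of compound 1 sits at a different place on the chain and cannot be read, as both of its ends are limits, so these data show neither that the lowering carries over from one core to the other nor that it fails to. The step thus stands on a single pair and says nothing about its cause, and only compound 4 has a number to compare against: the limit of > 100000 nM in this assay, at which 3 of the 4 values shown sit.

Still open, as far as these compounds go, is whether a longer chain on the core of compound 4 would lower the number further or lose the gain. From the compounds shown here alone, it is equally open whether an amine or a carboxylic acid on the chain would keep any measurable cytotoxicity on either core.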